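A few compounds are considered here, and "the series" means these few. Any claim that something is new, unique, unknown or untested is made for them only; others in the source may bear on it.

Working notes on the series. Compound 1 `CNc1cc(Oc2ccc(NC(=O)Nc3cccc(C)c3)cc2)ncn1` carries a methyl group on the terminal aryl ring; in an assay on isolated protein for inhibition of serine/threonine-protein kinase TNNI3K (Homo sapiens) (a higher number here means a weaker inhibitor, a lower number a stronger inhibitor), compound 1 gives 1260 nM. That is the highest of the three numbers in hand. Among the compounds with values here, compound 2 `CCNc1cc(Oc2ccc(NC(=O)Nc3cccc(C(F)(F)F)c3)cc2)ncn1` gives 25 nM in this assay, and compound 3 `CNc1cc(Oc2c(C)cc(NC(=O)Nc3cccc(C(F)(F)F)c3)cc2C)ncn1` gives 25 nM; both lie far below compound 1, well beyond the scatter, but each differs from compound 1 in more than one place, so no single structural step is isolated among the measured compounds.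

Compound 4 `CNc1cc(Oc2ccc(NC(=O)Nc3cccc(C(C)(C)C)c3)cc2)ncn1` has not yet been measured. It differs from compound 1 in one place only: tert-butyl in place of methyl on an aromatic carbon. Both compounds 2 and 3 carry a larger group than methyl at that place and give much lower numbers, though their other changes cloud the comparison. On that basis a step from compound 1 to compound 4 is expected downward, a 6.3-fold lower number from compound 1 to compound 4 (0.80 log units; beyond the scatter), of a size beyond the scatter but smaller than the gaps to compounds 2 and 3. The expected value for compound 4 in this assay is 200 nM, within a range of 50 nM to 800 nM.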

Compound 4, half-maximal inhibitory concentration: 40 nM
For compound 4 the middle estimate is 5.0-fold (0.70 log units) above the measured one, and the stated range ends above it.
By their numbers in this assay, from the lowest: compounds 2, 3 and 4 (each within the scatter of the next); then compound 1.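

In this assay, tert-butyl in place of methyl on an aromatic carbon gives a 32-fold lower number from compound 1 to compound 4 (1.50 log units; beyond the scatter) as a large step. This is the first change in the series isolated at a single place, so the position meta to a large group on the terminal ring is now shown to govern the number by itself, without the other differences that cloud compounds 2 and 3. Nothing in hand gives a reason for the size of this step.

The compounds shown leave open how groups of other sizes and kinds behave at this position, such as ethyl, isopropyl, an amine or a carboxylic acid. They also leave open how trifluoromethyl compares with tert-butyl on the core of compound 4, with no other place changed.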